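Shifting the Fluorine to 3-Fluorophenyl

The compounds below may be only part of what the source reports. "The series", "measured", "known", "first", "only" and "open" are said of these compounds alone.

Compound 1 `CNC(=O)[C@@H](CO)NCc1ccc(OCc2cccc(OC)c2)cc1`: 109 mg/kg
Compound 2 `CNC(=O)[C@@H](CO)NCc1ccc(OCc2ccc(Cl)cc2)cc1`: 216 mg/kg
Compound 3 `CNC(=O)[C@@H](CO)NCc1ccc(OCc2ccccc2F)cc1`: 12.4 mg/kg

In a functional assay on the whole organism with Mus musculus as the target (a higher number here means that more compound is needed for the effect, a lower number that less compound is needed), compound 3 has the lowest number of the three. Compound 4 `CNC(=O)[C@@H](CO)NCc1ccc(OCc2cccc(F)c2)cc1` differs from it as follows: 3-fluorophenyl in place of 2-fluorophenyl on a saturated chain carbon bound to an oxygen on an aromatic ring. This places 3-fluorophenyl in place of 2-fluorophenyl on a saturated chain carbon bound to an oxygen on an aromatic ring. Among the measured compounds shown here, no measured step makes this exact swap. The closest evidence is a modest step, an 8.8-fold lower number from compound 1 to compound 3 (0.94 log units; beyond the scatter), and a large one, a 17-fold lower number from compound 2 to compound 3 (1.24 log units; beyond the scatter). Both reached 2-fluorophenyl from other groups, so losing it may raise the number, though probably by less. The expected step is a 2.8-fold higher number from compound 3 to compound 4 (0.45 log units; beyond the scatter). For compound 4, the estimate is 35 mg/kg, with an expected range of 10 mg/kg to 120 mg/kg.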

Compound 4, dose for half-maximal effect: 25.1 mg/kg
Compound 4: the middle estimate sits 1.4-fold (0.14 log units) above what was measured, within the range that was stated.
By their numbers in this assay, from the lowest: compound 3; then compound 4; then compounds 1 and 2 (each within the scatter of the next).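

Moving the fluorine, with the same atoms in the group, still shifts the number in this assay (a 2.0-fold higher number from compound 3 to compound 4 (0.31 log units; beyond the scatter)), so its place on the ring matters and not only its presence. The low numbers are also not confined to 2-fluorophenyl, since 3-fluorophenyl stays well ahead of both other groups (an 8.6-fold lower number from compound 2 to compound 4 (0.93 log units; beyond the scatter)) and (a 4.3-fold lower number from compound 1 to compound 4 (0.64 log units; beyond the scatter)). No measurement shown here accounts for these differences.

The compounds shown leave open how 4-fluorophenyl or plain phenyl would compare. They also leave open whether 2-chlorophenyl would match 2-fluorophenyl.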